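The compounds below may be only part of what the source reports. "The series", "measured", "known", "first", "only" and "open" are said of these compounds alone.

Measured so far in a functional assay on CCRF-CEM cells (Homo sapiens) for cytotoxicity, read by XTT assay, with a stated time of 3 days; on this read-out lower numbers stand for stronger inhibition and higher numbers for weaker inhibition:

Compound 1 `OC[C@H]1O[C@@H](n2cc(F)c3c(-c4ccco4)ncnc32)[C@H](O)[C@@H]1O`: 1400 nM
Compound 2 `OC[C@H]1O[C@@H](n2cc(F)c3c(-c4ccc[nH]4)ncnc32)[C@H](O)[C@@H]1O`: 410 nM
Compound 3 `OC[C@H]1O[C@@H](n2cc(F)c3c(-c4c[nH]cn4)ncnc32)[C@H](O)[C@@H]1O`: 1800 nM

Compound 1 stands at the upper end of this small set together with compound 3, and the two lie within the scatter of each other, with a 1.3-fold higher number from compound 1 to compound 3 (0.11 log units; within the scatter). Compound 2 lies clearly lower, as shown by a 3.4-fold lower number from compound 1 to compound 2 (0.53 log units; beyond the scatter) and by a 4.4-fold higher number from compound 2 to compound 3 (0.64 log units; beyond the scatter).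

The next compound, compound 4 `OC[C@H]1O[C@@H](n2cc(Cl)c3c(-c4ccco4)ncnc32)[C@H](O)[C@@H]1O`, keeps the furan-2-yl group of compound 1 and differs from it in one place: chloro in place of fluoro on an aromatic carbon. This puts chloro in place of fluoro on an aromatic carbon. Among the measured compounds shown here, no measured step touches that place. For the measured compounds named here, all three steps exchange the furan-2-yl, 1H-pyrrol-2-yl and 1H-imidazol-4-yl groups for one another, so they offer no direct precedent and only indicate how far this read-out has moved. With no evidence for a shift in either direction, no step beyond the scatter is expected in this assay, but the range is kept wide, given the modest size of a 4.4-fold higher number from compound 2 to compound 3 (0.64 log units; beyond the scatter). The estimated step is a 1.2-fold lower number from compound 1 to compound 4 (0.07 log units; within the scatter). The expected value for compound 4 is 1200 nM, with an estimated range from 350 nM to 4000 nM.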

Compound 4, half-maximal inhibitory concentration: 3800 nM
The estimate for compound 4 lay 3.2-fold (0.50 log units) below the measured number; low and high end bracket the measured number.
By their numbers in this assay, from the lowest: compound 2; then compounds 1 and 3 (each within the scatter of the next); then compound 4.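

Among the compounds shown here, the earlier compounds all carried fluoro on the aromatic carbon of the five-membered aromatic ring with 1 nitrogen and differed only in the furan-2-yl, 1H-pyrrol-2-yl and 1H-imidazol-4-yl groups, so compound 4 gives the first reading at this place. In this assay the exchange of fluoro for chloro, with the furan-2-yl group kept, gives a 2.7-fold higher number from compound 1 to compound 4 (0.43 log units; beyond the scatter) and thus moves the read-out beyond the scatter towards weaker inhibition, which shows that this position is not silent even when one heavy atom is replaced by one heavy atom. No measured property of these compounds bears on this shift, so the reason for it remains unknown.

Whether chloro moves the number the same way alongside the 1H-pyrrol-2-yl or 1H-imidazol-4-yl groups remains open, as the only pair shown for this change carries furan-2-yl. Also open, going by these compounds, is how a bromo, a methyl, a nitrile or an amine on this same aromatic carbon would stand against fluoro and chloro, and whether the read-out follows any order across such groups.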